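The source may hold more compounds than are shown below. What is called first, only, known or untested is meant among the compounds shown, and "the series" means these compounds.

For the measured compounds named here, compound 2, `COc1cc2nc([S+]([O-])CC(=O)Nc3ccc(C)cc3)nc(Nc3c(Cl)cc(/C=C/C#N)cc3Cl)c2cc1OC`, is the one compound here with an actual number in an ADME assay on MT4 cells (Homo sapiens) for cytotoxicity, read by MTT assay, with a stated time of 5 days; a higher number here means that more compound is tolerated, a lower number that less compound is tolerated: compound 2 gives 32200 nM. Compound 1, `COc1cc2nc([S+]([O-])CC(=O)Nc3ccc(S(N)(=O)=O)cc3)nc(Nc3c(Cl)cc(/C=C/C#N)cc3Cl)c2cc1OC`, gives only a limit in this assay, > 189000 nM, as the limit of > 189000 nM in this assay, at which 1 of the 2 values shown sits, records. Going by the values given here, the one measured step, an at least 5.8-fold lower number from compound 1 to compound 2 (0.76 log units; beyond the scatter), runs from that limit to the number for compound 2.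

Compound 3, `COc1cccc(NC(=O)C[S+]([O-])c2nc(Nc3c(Cl)cc(/C=C/C#N)cc3Cl)c3cc(OC)c(OC)cc3n2)c1`, is not yet measured. It differs from compound 2 by 3-methoxyphenyl in place of 4-methylphenyl on an amide-type nitrogen. Among the compounds with values here, no measured step touches this part of the molecule: the single step known concerns methyl in place of sulfamoyl on an aromatic carbon, and says nothing about a 3-methoxyphenyl against a 4-methylphenyl. Within the data shown here, with no step to go on, the expected change from compound 2 to compound 3 in this assay is a 1.1-fold higher number from compound 2 to compound 3 (0.04 log units; within the scatter), within the scatter in either direction. Compound 3 is therefore estimated at 35000 nM, with a range from 12000 nM to 100000 nM.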

Compound 3, half-maximal cytotoxic concentration: >= 167000 nM
Compound 3: no number, only a limit; the forecaster's own chance of this, stated with the estimate: 15%; at least 4.7-fold (0.67 log units) between middle value and limit.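

In this assay, 3-methoxyphenyl in place of 4-methylphenyl on the amide-type nitrogen gives an at least 5.1-fold higher number from compound 2 to compound 3 (0.71 log units; beyond the scatter), so this position alters the read-out even without the sulfamoyl group that compound 1 carries. Compound 3 gives no actual number, only a limit: the limit of >= 167000 nM in this assay, at which 1 of the 3 values shown sits. Compound 2 thus remains the only one of the three with a number, while compound 1 and compound 3 both stand as limits, and the step between those two cannot be read.

The compounds shown leave open whether the change in compound 3 comes from the methoxy group, from its place on the ring or from the loss of the methyl. They also leave open how an amine or a carboxylic acid on this phenyl ring would read in this assay.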